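The compounds below may be only part of what the source reports. "The series", "measured", "known", "first", "only" and "open" are said of these compounds alone.

Measured compounds:
compound 1 `CCn1nc(C)c2c1CCN(C(C(=O)NC)c1ccccc1)C2CCc1ccccc1F` — 669 nM
compound 2 `CCn1nc(C)c2c1CCN(C(C(=O)NC)c1ccccc1)C2CCc1ccc(OC)cc1` — 10000 nM

In a functional assay on CHO cells for antagonist activity at Orexin/Hypocretin receptor type 1 (Homo sapiens), read by FLIPR and calcium flux (a higher number here means a weaker inhibitor, a lower number a stronger inhibitor), compound 2 gives 10000 nM, the highest of the two numbers; compound 1 stands at 669 nM. For the measured compounds named here, the one measured step, a 15-fold higher number from compound 1 to compound 2 (1.17 log units; beyond the scatter), is large and shows that the group on the saturated chain carbon, two bonds along the chain from a saturated ring carbon, moves the number a long way. Compound 3 `CCn1nc(C)c2c1CCN(C(C(=O)NC)c1ccccc1)C2CCc1cccc(C)c1` differs from compound 2 by 3-methylphenyl in place of 4-methoxyphenyl on a saturated chain carbon, two bonds along the chain from a saturated ring carbon. Going by the values given here, no measured compound carries 3-methylphenyl at this place, so the measured step bears on the coming change only through its size, not its direction. Since compound 2 is the weaker of the two and the methoxy leaves, a lower number is expected, with the estimated step of a 3.3-fold lower number from compound 2 to compound 3 (0.52 log units; beyond the scatter), though the range is wide. Compound 3 is estimated at 3000 nM, between 700 nM and 12000 nM.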

Compound 3, half-maximal inhibitory concentration: 180 nM
The estimate for compound 3 lay 17-fold (1.22 log units) above the measured number; the measured number lies below the stated range.
By their numbers in this assay, from the lowest: compound 3; then compound 1; then compound 2.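

In this assay, the aryl group on a saturated chain carbon, two bonds along the chain from a saturated ring carbon, can bring the number below that of compound 1 as well as raise it: 3-methylphenyl for 2-fluorophenyl gives a 3.7-fold lower number from compound 1 to compound 3 (0.57 log units; beyond the scatter) and is modest, so compound 3 now sets the low end of the three. The change from 4-methoxyphenyl to 3-methylphenyl gives a 56-fold lower number from compound 2 to compound 3 (1.74 log units; beyond the scatter) and is large, but it alters both the substituent and its ring position in one step. No available evidence bears on why the number moves so far.

The effects of substituent and ring position remain unseparated, which 3-methoxyphenyl and 4-methylphenyl at this place would address. Also open, from the compounds shown here alone, is how the number responds to 3-chlorophenyl, or to a pyridyl ring in place of the phenyl.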